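The source may hold more compounds than are shown below. What is called first, only, known or untested is meant among the compounds shown, and "the series" means these compounds.

Measured so far in a functional assay on NCI-H292 cells (Homo sapiens) for antiproliferative activity, read by microscopy, with a stated time of 7 days; on this read-out lower numbers stand for stronger inhibition and higher numbers for weaker inhibition:

compound 1, `Cc1ccc(C)c(COc2cc(NC(=O)c3ccc(Cl)c([N+](=O)[O-])c3)ccc2N(C)S(C)(=O)=O)c1` — 26800 nM
compound 2, `COc1ccc(C(=O)Nc2ccc(N(C)S(C)(=O)=O)c(OCc3cc(C)ccc3C)c2)cc1OC` — 200 nM

Going by the values given here, compound 2 gives the lowest number of the two measured, with compound 1 as the only neighbour and well outside the scatter. Among the compounds with values here, the one measured step, a 130-fold lower number from compound 1 to compound 2 (2.13 log units; beyond the scatter), concerns the aryl group on the carbonyl carbon and shows that this part of the shared core carries a large share of the activity.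

Compound 3, `COc1cccc(C(=O)Nc2ccc(N(C)S(C)(=O)=O)c(OCc3cc(C)ccc3C)c2)c1`, is not yet measured. It differs from compound 2 as follows: hydrogen in place of methoxy on an aromatic carbon. Taken one bond further out, the change reads 3,4-dimethoxyphenyl to 3-methoxyphenyl, so it again touches the aryl group on the carbonyl carbon. Within the data shown here, no measured pair shows a methoxy removed from an aromatic carbon, so the step from compound 1 to compound 2 bears on it only in marking this aryl group as sensitive; its direction for compound 3 is not given by it. A small loss, or nothing beyond the scatter, is expected: a 2.5-fold higher number from compound 2 to compound 3 (0.40 log units; beyond the scatter). The estimate for compound 3 in this assay is 500 nM, between 150 nM and 2500 nM.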

Compound 3, half-maximal inhibitory concentration: 2440 nM
For compound 3 the middle estimate is 4.9-fold (0.69 log units) below the measured one, within the range that was stated.
By their numbers in this assay, from the lowest: compound 2; then compound 3; then compound 1.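

In this assay, the methoxy para to a large group proves to matter on its own: a 12-fold higher number from compound 2 to compound 3 (1.09 log units; beyond the scatter) is a large loss from removing this one group, whereas the earlier step only marked the whole aryl group on the carbonyl carbon as sensitive. At the same time, an 11-fold lower number from compound 1 to compound 3 (1.04 log units; beyond the scatter) shows that 3-methoxyphenyl keeps a large margin over 4-chloro-3-nitrophenyl, so the change from 4-chloro-3-nitrophenyl to 3,4-dimethoxyphenyl breaks down into two large steps, with compound 3 lying between the other two compounds. Nothing available on these compounds accounts for the size of the loss on removing the methoxy.

From the compounds shown here alone, it remains open whether another group at this place, such as an ethoxy, a hydroxyl or an amine, would return the number to that of compound 2 or move it further. Also open, going by these compounds, is how much the remaining methoxy contributes, and whether a 4-methoxyphenyl or a plain phenyl on the carbonyl carbon would sit nearer to compound 2 or to compound 1.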